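Adding a second fluoro to the aryl urea series

This account rests on a few compounds, and the source may have more. Where it says the series, first, only, none or still open, it means among the compounds named here.

Compound 1, `Cc1ccccc1NC(=O)N[C@H](C)c1ccccc1`: 100%
Compound 2, `COc1ccccc1NC(=O)N[C@H](C)c1ccccc1`: 105%
Compound 3, `C[C@@H](NC(=O)Nc1ccccc1F)c1ccccc1`: 95%

Three ureas have been measured in an ADME assay on the whole organism with Oryza sativa as the target, tested at 1 uM; a lower number here means a stronger effect, a higher number a weaker effect of the compound at the concentration tested. Compound 1 (`Cc1ccccc1NC(=O)N[C@H](C)c1ccccc1`) gives 100%, compound 2 (`COc1ccccc1NC(=O)N[C@H](C)c1ccccc1`) gives 105%, and compound 3 (`C[C@@H](NC(=O)Nc1ccccc1F)c1ccccc1`) gives 95%. The step of a number 5 percentage points lower from compound 1 to compound 3 (within the scatter) and the step of a number 10 percentage points lower from compound 2 to compound 3 (within the scatter) show that compound 3 sits within the scatter of both other compounds; the three numbers cannot be told apart.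

Compound 4 (`C[C@@H](NC(=O)Nc1cccc(F)c1F)c1ccccc1`) differs from compound 3 by fluoro in place of hydrogen on an aromatic carbon. Within the data shown here, the steps that bear on this change are those that alter the substituent on the same aromatic ring: a number 5 percentage points higher from compound 1 to compound 2 (within the scatter) and a number 5 percentage points lower from compound 1 to compound 3 (within the scatter), both within the scatter. On this basis no step beyond the scatter is expected for compound 4 in this assay, so the step of no change at the digits printed from compound 3 to compound 4 (within the scatter) is estimated to be small. Compound 4 is therefore expected to give about 95%, between 80% and 108%.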

Compound 4, a percentage reported as activity, at one concentration (the size of the read-out at that concentration, not a potency): 99%
Compound 4: middle estimate off by 4 percentage points, on the low side; the measured number falls inside the stated range.
By their numbers in this assay, from the lowest: compounds 3, 4, 1 and 2 (each within the scatter of the next).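

In this assay, among these compounds, compounds 1 to 3 varied only a single group on the aromatic ring, whereas compound 4 keeps the fluoro of compound 3 and brings a second fluoro to a carbon that carries hydrogen in all three earlier compounds, ortho to a fluoro group and meta to a large group. The step, a number 4 percentage points higher from compound 3 to compound 4 (within the scatter), shows that exchanging hydrogen for fluoro at this position leaves the read-out indistinguishable at the concentration tested. No measurement is at hand that could explain this result.

On these data alone, whether an amine, a carboxylic acid or a longer chain at this position would give a step beyond the scatter remains open. So does whether a fluoro here would behave alike with methyl or methoxy in the place of the first fluoro, as in compound 1 and compound 2.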